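Expected cytotoxicity after a bromophenylsulfonyl-for-phenylpropyl exchange

The compounds below may be only part of what the source reports. "The series", "measured", "known", "first", "only" and "open" are said of these compounds alone.

Three compounds on one shared core have been run in a functional assay on HEK293 cells (Homo sapiens) for cytotoxicity; on this read-out lower numbers stand for higher toxicity in this test and higher numbers for lower toxicity in this test. Compound 1 `COc1ccc([C@H]2CC(=O)N(c3cc(N)cc(F)c3)C2)cc1OC1CCCC1` reaches only the limit of the test, > 10000 nM. Compound 2 `COc1ccc([C@H]2CC(=O)N(c3ccccc3C#N)C2)cc1OC1CCCC1` likewise sits at the limit, > 10000 nM. The step that the two limits leave unreadable from compound 1 to compound 2 is therefore unreadable. Compound 3 `COc1ccc([C@H]2CC(=O)N(c3cccc(NCCCc4ccccc4)c3)C2)cc1OC1CCCC1` also stops at the limit, > 10000 nM. All three values are limits rather than numbers, as the limit of > 10000 nM in this assay, at which 3 of the 3 values shown sit, records. Compound 4 `COc1ccc([C@H]2CC(=O)N(c3cccc(NS(=O)(=O)c4cccc(Br)c4)c3)C2)cc1OC1CCCC1` differs from compound 3 by (3-bromophenyl)sulfonyl in place of 3-phenylpropyl on a nitrogen on an aromatic ring. Within the data shown here, no measured step bears on this change: every value shown is a limit. Compound 4 is therefore expected to remain at the limit, the step that the limit leaves unreadable from compound 3 to compound 4 meaning nothing readable beyond the scatter. Compound 4 is estimated at 20000 nM, expected between 8000 nM and 60000 nM.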

Compound 4, half-maximal cytotoxic concentration: > 10000 nM
Compound 4 ended at the assay's limit; the forecaster's own chance of this, stated with the estimate: 80%; the middle value is on the limit's open side.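

No step can be read between compound 3 and compound 4 in this assay, since both stop at a limit of the test: the limit of > 10000 nM in this assay, at which 4 of the 4 values shown sit. What the compounds shown leave open is which change on the shared core would give a value short of that limit.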